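The compounds below may be only part of what the source reports. "The series", "measured", "known", "first", "only" and "open" are said of these compounds alone.

Measured so far:
compound 1, `CNc1nc(NCCCN(C)C)c2sc(-c3ccc(S(C)(=O)=O)cc3)cc2n1`: 15 uL/min
compound 2, `CNc1nc(NCCCN(C)C)c2sc(-c3cncnc3)cc2n1`: < 17 uL/min

Both were run in an ADME assay (liver) for metabolic stability, with Liver microsome (Homo sapiens) as the target, read by LC-MS, using microsomes, tested at 1 uM; a higher number here means faster removal of the compound, a lower number slower removal. Among the compounds with values here, compound 1 gives 15 uL/min, which is the only plain number in the set. For compound 2 the result is a limit and not a number, (the limit of < 17 uL/min in this assay, at which 1 of the 2 values shown sits). Within the data shown here, no pair of measured compounds differs in a single place, so the two values give no sense of how one structural change moves the read-out in this assay .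

Compound 3, `CNc1nc(NCCCN(C)C)c2sc(-c3ccccc3)cc2n1`, differs from compound 1 in one place: hydrogen in place of methylsulfonyl on an aromatic carbon. Among the measured compounds shown here, with no measured step to lean on, the step that the estimate below implies, a 1.3-fold higher number from compound 1 to compound 3 (0.12 log units; within the scatter), is expected to be small, leaning toward faster removal, and of a size that sits within the usual scatter of this assay . Compound 3 is therefore estimated at 20 uL/min in this assay , with a range from 10 uL/min to 40 uL/min. A limit rather than a number cannot be ruled out for compound 3, and the measured value will decide.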

Compound 3, intrinsic clearance in a liver preparation (reported as CLH), per the amount of preparation that the assay uses: 5 uL/min
Estimate against measurement, compound 3: 4.0-fold (0.60 log units) above, outside the stated range (below it).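

In this assay, the series now has its first readable single change: hydrogen in place of methylsulfonyl on an aromatic carbon gives a 3.0-fold lower number from compound 1 to compound 3 (0.48 log units; beyond the scatter). The group at this place on the six-membered aromatic ring therefore registers in the read-out, and the unsubstituted phenyl ring of compound 3 carries the lower number of the pair, pointing to slower removal. Compound 2 still gives a limit and not a number, so the step from phenyl to pyrimidin-5-yl cannot be read: the limit of < 17 uL/min in this assay, at which 1 of the 3 values shown sits.

One step from methylsulfonyl to hydrogen does not show whether the higher number belongs to methylsulfonyl alone or would also appear with another group at the same place, such as a methoxy group, an amine or a carboxylic acid. The compounds shown also keep the rest of the core and its side chains fixed, so how the read-out answers a change elsewhere, for example a shorter or longer chain in place of the amine-bearing one, stays open.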